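Swapping the Methylphenyl for a Methylpyrrole on the Carbonyl

This account rests on a few compounds, and the source may have more. Where it says the series, first, only, none or still open, it means among the compounds named here.

Compound 1 `COCOc1cccc(C(=O)/C=C/c2ccc3c(c2)B(O)OC3)c1` gives in an ADME assay on L929 cells (Mus musculus) for cytotoxicity, read by resazurin assay, with a stated time of 72 h (a higher number here means a weaker inhibitor, a lower number a stronger inhibitor), the assay limit > 10 ug/mL.
Compound 2 `Cc1cccc(C(=O)/C=C/c2ccc3c(c2)B(O)OC3)c1` gives 8.56 ug/mL.
Compound 3 `COc1cccc(C(=O)/C=C/c2ccc3c(c2)B(O)OC3)c1` gives the assay limit > 10 ug/mL.

Within the data shown here, compound 2 thus holds the only actual number among the three; the other two values are limits, as the limit of > 10 ug/mL in this assay, at which 2 of the 3 values shown sit, records. The measured steps of an at least 1.1-fold lower number from compound 1 to compound 2 (0.06 log units; that floor lies within the scatter) and an at least 1.1-fold higher number from compound 2 to compound 3 (0.06 log units; that floor lies within the scatter) both sit at a floor within the scatter and both concern the group on an aromatic carbon. Compound 4 `Cn1cccc1C(=O)/C=C/c1ccc2c(c1)B(O)OC2` changes a different place: 1-methyl-1H-pyrrol-2-yl in place of 3-methylphenyl on a carbonyl carbon. Among the measured compounds shown here, no measured step touches the carbonyl carbon, so nothing here points to a step beyond the scatter, and a step of a 1.2-fold higher number from compound 2 to compound 4 (0.07 log units; within the scatter) is expected. Compound 4 is therefore estimated at 10 ug/mL, within a range from 5 ug/mL to 20 ug/mL.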

Compound 4, half-maximal inhibitory concentration: > 10 ug/mL
Compound 4 was reported as a limit; the forecaster's own chance of this, stated with the estimate: 55%; the middle value lies on the limit itself.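

Putting 1-methyl-1H-pyrrol-2-yl in place of 3-methylphenyl on the carbonyl carbon gives an at least 1.1-fold higher number from compound 2 to compound 4 (0.06 log units; that floor lies within the scatter). In this assay compound 4 gives > 10 ug/mL, which is a limit and not a number. This first change at the carbonyl carbon thus shows no step beyond the scatter, and compound 2 still holds the only actual number: the limit of > 10 ug/mL in this assay, at which 3 of the 4 values shown sit.

On these data alone, how far the true value of compound 4 lies beyond that floor stays open. So does the reading at this carbonyl carbon for a pyridine ring or a phenyl ring carrying a carboxylic acid.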